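The source may hold more compounds than are shown below. What is called first, only, known or untested is meant among the compounds shown, and "the series" means these compounds.

Compounds with measured values:
compound 1 `Cc1c(O)ccc2c1[C@H](Cn1cc(-c3ccc(Cl)cc3)nn1)[C@@]13CC(=O)[C@@](C)(CC[C@@H]21)C3` — > 20000 nM
compound 2 `Cc1ccc(S(=O)(=O)Oc2ccc3c(c2C)[C@H](Cn2cc(-c4ccc(Cl)cc4)nn2)[C@@]24CC(=O)[C@@](C)(CC[C@@H]32)C4)cc1` — > 20000 nM
compound 3 `C=C1C(=O)[C@]23C[C@@]1(O)CC[C@H]2c1ccc(O)c(C)c1[C@@H]3Cn1cc(-c2ccc(C(F)(F)F)cc2)nn1` — 1440 nM

The read-out throughout is a functional assay on SMMC-7721 cells (Homo sapiens) for cytotoxicity, read by MTT assay, with a stated time of 4 days; a higher number here means a weaker inhibitor, a lower number a stronger inhibitor. Compound 1 gives > 20000 nM, which is a limit of this assay and not a number. Compound 2 gives > 20000 nM, likewise a limit and not a number. Going by the values given here, compound 3, whose core carries an additional hydroxyl and an exocyclic methylene and whose triazole aryl bears trifluoromethyl instead of chloro, gives 1440 nM; no single-point step connects it to compound 1, so the two values are simply noted side by side.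

Among the compounds with values here, the one measured step that touches compound 1, a step that the two limits leave unreadable from compound 1 to compound 2, runs between two limits and its size cannot be read. Compound 1 thus stands at the limit of > 20000 nM in this assay, at which 2 of the 3 values shown sit, with no readable step from it in either direction.

Compound 4 `Cc1ccc(-c2cn(C[C@H]3c4c(ccc(O)c4C)[C@@H]4CC[C@@]5(C)C[C@]43CC5=O)nn2)cc1` differs from compound 1 by methyl in place of chloro on an aromatic carbon. Within the data shown here, no measured step bears on that change. With compound 1 at a limit and nothing to show that exchanging chloro for methyl moves the value beyond the scatter, compound 4 is expected to sit close to compound 1, and the step of a number no higher from compound 1 to compound 4 (the limit leaves the size open) is estimated as none beyond the scatter. Compound 4 is therefore expected to give about 20000 nM, within 8000 nM to 50000 nM.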

Compound 4, half-maximal inhibitory concentration: > 20000 nM
Compound 4 gave a limit, no number; the forecaster's own chance of this, stated with the estimate: 70%; the middle value lies on the limit itself.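

In this assay compound 4 gives > 20000 nM, a limit and not a number. Compound 1 also stands at a limit, so no step between compound 1 and compound 4 can be read: the limit of > 20000 nM in this assay, at which 3 of the 4 values shown sit.

The compounds shown leave open whether methyl in place of chloro on an aromatic carbon changes the value at all.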